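The source may report more compounds than this note shows. Statements on the series, on what has been measured and on what is new or still open speak of the compounds shown alone.

Measured so far:
compound 1 `O=C(NC1CCN(Cc2cccc(C(F)(F)F)c2)CC1)c1ccc2ccccc2c1`, 103 nM
compound 2 `COc1cccc(CN2CCC(NC(=O)c3ccc4ccccc4c3)CC2)c1`, 16 nM

In an assay on isolated protein for displacement of a labelled ligand from D(4) dopamine receptor (Homo sapiens) (a lower number here means a stronger inhibitor, a higher number a weaker inhibitor), compound 2 stands lowest of the two numbers; its nearest neighbour is compound 1, the two linked by a 6.4-fold lower number from compound 1 to compound 2 (0.81 log units; beyond the scatter). Compound 3 `Cc1ccc(CN2CCC(NC(=O)c3ccc4ccccc4c3)CC2)cc1` differs from compound 2 by 4-methylphenyl in place of 3-methoxyphenyl on a saturated chain carbon bound to an amine nitrogen in a ring. Among the measured compounds shown here, the one measured step, a 6.4-fold lower number from compound 1 to compound 2 (0.81 log units; beyond the scatter), swaps a different pair of groups on that ring and is only a loose guide here. A modest weakening is expected, a 2.2-fold higher number from compound 2 to compound 3 (0.34 log units; beyond the scatter), near the edge of the scatter. Compound 3 is therefore estimated at 35 nM, within 10 nM to 120 nM.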

Compound 3, inhibition constant: 21 nM
Compound 3: middle estimate off by 1.7-fold (0.22 log units), on the high side; the range from low to high includes it.
By their numbers in this assay, from the lowest: compounds 2 and 3 (each within the scatter of the next); then compound 1.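

In this assay, 4-methylphenyl and 3-methoxyphenyl on a saturated chain carbon bound to an amine nitrogen in a ring cannot be told apart (a 1.3-fold higher number from compound 2 to compound 3 (0.12 log units; within the scatter)), so a group with no hydrogen-bond acceptor serves here as well as one with an acceptor. The gap to compound 1 persists with this second group (a 4.9-fold lower number from compound 1 to compound 3 (0.69 log units; beyond the scatter)), which leaves 3-(trifluoromethyl)phenyl alone at the higher number. Nothing at hand explains either step. Because the group and its ring position change together from compound 2 to compound 3, their contributions remain unseparated. Going by these compounds, how 3-methylphenyl, 4-methoxyphenyl or a ring bearing a carboxylic acid or an amine would read at this position stays open.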